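From Aryl Amide to Cyclobutyl Amide on a Shared Core

The source may report more compounds than this note shows. Statements on the series, on what has been measured and on what is new or still open speak of the compounds shown alone.

Three compounds share one core and differ only in the group attached to the carbonyl carbon of the amide. In an assay on isolated protein for inhibition of aldehyde dehydrogenase 1A1 (Homo sapiens), read by spectrophotometry, tested at 10 uM (a higher number here means more inhibition at the concentration tested (going by the name of the read-out), a lower number less inhibition), compound 1 `Cc1cccc(Cn2c(CN3CCN(C(=O)c4ccc(Br)cc4)CC3)nc3ccccc32)c1` gives 25.8%, compound 2 `Cc1cccc(Cn2c(CN3CCN(C(=O)C(C)C)CC3)nc3ccccc32)c1` gives 87.2%, and compound 3 `Cc1cccc(Cn2c(CN3CCN(C(=O)c4ccc(F)cc4)CC3)nc3ccccc32)c1` gives 27.1%. Compound 3 thus stands second highest of the three numbers; its value and that of compound 1 lie within the scatter of each other (a number 1.3 percentage points higher from compound 1 to compound 3 (within the scatter)), while compound 2 sits far above it (a number 60.1 percentage points lower from compound 2 to compound 3 (beyond the scatter)).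

Compound 4 `Cc1cccc(Cn2c(CN3CCN(C(=O)C4CCC4)CC3)nc3ccccc32)c1` has not yet been measured. Relative to compound 3 the change is cyclobutyl in place of 4-fluorophenyl on a carbonyl carbon. The measured steps that bear on this are the two that exchanged an aryl group for an alkyl group on the carbonyl carbon: a number 61.4 percentage points higher from compound 1 to compound 2 (beyond the scatter) and, in the opposite direction, a number 60.1 percentage points lower from compound 2 to compound 3 (beyond the scatter). Both were large. Cyclobutyl, like isopropyl, is a saturated carbon group, so a step of similar size and direction, toward the level of compound 2, is expected: a number 52.9 percentage points higher from compound 3 to compound 4 (beyond the scatter). Whether a ring rather than a branched chain alters the outcome cannot be judged from these three compounds. The estimate for compound 4 in this assay is therefore 80%, with a range from 60% to 95%.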

Compound 4, a percentage reported as inhibition, at one concentration (the size of the read-out at that concentration, not a potency): 69.1%
For compound 4 the middle estimate is 10.9 percentage points above the measured one; the measured number falls inside the stated range.
By their numbers in this assay, from the lowest: compounds 1 and 3 (each within the scatter of the next); then compound 4; then compound 2.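

In this assay, the rise seen with isopropyl is not confined to that one group: cyclobutyl on the same carbonyl carbon also stands well clear of both aryl amides, with a number 42 percentage points higher from compound 3 to compound 4 (beyond the scatter) and a number 43.3 percentage points higher from compound 1 to compound 4 (beyond the scatter). The new compound also shows that the saturated groups are not interchangeable at this position, since there is a number 18.1 percentage points lower from compound 2 to compound 4 (beyond the scatter), a smaller step than either of those from the aryl amides but still one that can be read. Among these four compounds, then, the level depends both on whether an aryl or a saturated carbon group sits on the carbonyl carbon and on which saturated group it is, and nothing in hand accounts for either difference.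

Going by these compounds, with only isopropyl and cyclobutyl as saturated groups, it remains open where cyclopropyl, cyclohexyl, tert-butyl or a longer chain such as n-butyl would fall relative to compound 2 and compound 4. On these data alone, it is also open whether an amine or a carboxylic acid on the cyclobutyl ring, or an unsubstituted phenyl in place of the halogenated rings, would change the level at this position.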